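Compound 2 to compound 4: a new group on the carbonyl

This account rests on a few compounds, and the source may have more. Where it says the series, first, only, none or still open, it means among the compounds named here.

In an ADME assay on HEK293 cells (Homo sapiens) for cytotoxicity (on this read-out lower numbers stand for stronger inhibition and higher numbers for weaker inhibition), compound 2 (`COCC(=O)N1C[C@H](NC(=O)c2ccc(-n3ccccc3=O)cc2)[C@H](NC(=O)c2ccc(Cl)s2)C1`) gives > 100000 nM as a limit of the assay and not a number. Compound 1 (`CCC(=O)N1C[C@H](NC(=O)c2ccc(-n3ccccc3=O)cc2)[C@H](NC(=O)c2ccc(Cl)s2)C1`) gives > 100000 nM as a limit as well. Compound 3 (`CC(C)S(=O)(=O)N1C[C@H](NC(=O)c2ccc(-n3ccccc3=O)cc2)[C@H](NC(=O)c2ccc(Cl)s2)C1`) gives > 100000 nM as a limit as well. Among the measured compounds shown here, the series so far stands at the limit of > 100000 nM in this assay, at which 3 of the 3 values shown sit, and compound 2 has no number of its own.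

Compound 4 (`O=C(N[C@H]1CN(C(=O)N2CCCC2)C[C@H]1NC(=O)c1ccc(Cl)s1)c1ccc(-n2ccccc2=O)cc1`) differs from compound 2 by pyrrolidin-1-yl in place of methoxymethyl on a carbonyl carbon and is so far unmeasured. For the measured compounds named here, three measured steps bear on this change: a step that the two limits leave unreadable from compound 1 to compound 2 and a step that the two limits leave unreadable from compound 1 to compound 3 and a step that the two limits leave unreadable from compound 2 to compound 3 and none of them yields a size. Going by the values given here, no measured step therefore points to a shift in either direction. The expected step is a number no higher from compound 2 to compound 4 (the limit leaves the size open) with nothing beyond the scatter foreseen. The estimate for compound 4 is 100000 nM with 50000 nM to 200000 nM as its expected range, and a report as a limit is the likely outcome.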

Compound 4, half-maximal inhibitory concentration: > 100000 nM
Compound 4: no number, only a limit (the forecaster's own chance of this, stated with the estimate: 90%); the middle value lies on the limit itself.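

Compound 4 gives a limit and not a number, so its steps to compound 1, compound 2 and compound 3 cannot be read in this assay: the limit of > 100000 nM in this assay, at which 4 of the 4 values shown sit. The compounds shown leave open whether these groups on the amine nitrogen in a ring differ at all in this read-out.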